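Chloro for isopropyl on a shared core

The source may hold more compounds than are shown below. What is called first, only, known or untested is meant among the compounds shown, and "the series" means these compounds.

Compound 2 `COc1cc(-c2nc(SCc3cn(CC(=O)NC(=O)Nc4ccccn4)nn3)nc(Nc3ccc(C(C)C)cc3)c2C#N)cc(OC)c1OC` gives 1210 nM in a functional assay on B16-F10 cells (Mus musculus) for inhibition, read by MTT assay, with a stated time of 72 h; a lower number here means a stronger inhibitor, a higher number a weaker inhibitor.
Compound 1 `CC(C)c1ccc(-c2nc(SCc3cn(CC(=O)NC(=O)Nc4ccccn4)nn3)nc(Nc3ccc(Cl)cc3)c2C#N)cc1` gives 860 nM in this assay.

Compound 2 has the highest of the two numbers, and compound 1 sits within the scatter of it. Compound 3 `COc1cc(-c2nc(SCc3cn(CC(=O)NC(=O)Nc4ccccn4)nn3)nc(Nc3ccc(Cl)cc3)c2C#N)cc(OC)c1OC` has not been measured. It differs from compound 2 in one place: chloro in place of isopropyl on an aromatic carbon, turning a (4-isopropylphenyl)amino into a (4-chlorophenyl)amino. Among the compounds with values here, no measured pair shows this exact change, so compound 3 is expected to sit within the scatter of compound 2, with a step of a 1.2-fold lower number from compound 2 to compound 3 (0.08 log units; within the scatter) in this assay. Compound 3 is estimated at 1000 nM, with a range from 400 nM to 2500 nM.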

Compound 3, half-maximal inhibitory concentration: 1110 nM
Beside the measured number, compound 3's estimate is 1.1-fold (0.05 log units) below it; the measured number falls inside the stated range.
By their numbers in this assay, from the lowest: compounds 1, 3 and 2 (each within the scatter of the next).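

Within the data shown here, with the 3,4,5-trimethoxyphenyl group held in place, the first direct reading of chloro in place of isopropyl on this aromatic carbon in this assay is within the scatter (a 1.1-fold lower number from compound 2 to compound 3 (0.04 log units; within the scatter)), so the two groups cannot be told apart here. With the (4-chlorophenyl)amino group held in place, 3,4,5-trimethoxyphenyl in place of 4-isopropylphenyl is also within the scatter (a 1.3-fold higher number from compound 1 to compound 3 (0.11 log units; within the scatter)). No evidence is available to explain either reading. The compounds shown leave open whether an amine or a carboxylic acid at this place would give a number beyond the scatter. They also leave open whether a longer chain than isopropyl would do so.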